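This account rests on a few compounds, and the source may have more. Where it says the series, first, only, none or still open, it means among the compounds named here.

Of the compounds shown here, three built on one shared core have been measured in a functional assay (B cells) with Mus musculus as the target; on this read-out higher numbers stand for an effect only at larger amounts of compound and lower numbers for an effect already at smaller amounts. Compound 1 `C=CCn1c(=O)n(CCCCCCCC)c2nc(N)nc(O)c21` gives 37 uM in this assay. Compound 3 `C=CCn1c(=O)n([C@@H]2O[C@H](CO)[C@H]3OC(=O)O[C@H]32)c2nc(N)nc(O)c21` gives 3 uM. Compound 2 `Nc1nc(O)c2c(n1)n(C1OC(CO)[C@@H](O)[C@H]1O)c(=O)n2CC(O)CSc1ccccc1` gives 142 uM, the highest of the three numbers; its gap to compound 1 lies beyond the usual scatter, and its gap to compound 3 is larger still, so compound 2 needs the largest amount of the three to reach a half-maximal effect. Compound 4 `NC(=O)Cn1c(=O)n(C2OC(CO)[C@@H](O)[C@H]2O)c2nc(N)nc(O)c21` has not yet been measured. It differs from compound 2 in a single place: carbamoyl in place of 1-hydroxy-2-(phenylsulfanyl)ethyl on a saturated chain carbon bound to an aromatic nitrogen. For the measured compounds named here, no two measured compounds differ in only one place, and compound 1 and compound 3 differ from compound 2 in several places at once, so the weight of this particular change cannot be read directly from the data. Because compound 2 sits at 142 uM while compound 1 and compound 3 both sit lower, a moderate downward step is expected rather than none. Compound 4 is expected at about 60 uM, with a range from 15 uM to 250 uM. That estimate amounts to an expected step of a 2.4-fold lower number from compound 2 to compound 4 (0.37 log units; beyond the scatter).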

Compound 4, concentration for half-maximal effect: 190 uM
For compound 4 the middle estimate is 3.2-fold (0.50 log units) below the measured one, within the range that was stated.
By their numbers in this assay, from the lowest: compound 3; then compound 1; then compounds 2 and 4 (each within the scatter of the next).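

On a saturated chain carbon bound to an aromatic nitrogen, carbamoyl in place of 1-hydroxy-2-(phenylsulfanyl)ethyl gives a 1.3-fold higher number from compound 2 to compound 4 (0.13 log units; within the scatter) in this assay. In this one pair, the six-membered aromatic ring and the sulfur both leave and the group shrinks from 10 heavy atoms to 3, yet the read-out shows no change beyond the usual scatter. No measurement is at hand that explains this result.

On these data alone, whether another group at this place, such as a primary amine, a carboxylic acid or a longer alkyl chain, would shift the number beyond the scatter remains open. A single pair also leaves open whether the same exchange would give a similar step if another part of the shared core were different.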